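A few compounds are considered here, and "the series" means these few. Any claim that something is new, unique, unknown or untested is made for them only; others in the source may bear on it.

Working notes on the series. In a functional assay (B cells) with Mus musculus as the target (on this read-out lower numbers stand for an effect already at smaller amounts and higher numbers for an effect only at larger amounts of compound), compound 1 (`Nc1nc(O)c2c(n1)n(C1OC(CO)[C@@H](O)[C@H]1O)c(=O)n2C/C=C/c1ccccc1`) gives 103 uM and lies within the scatter of both other measured compounds. Compound 3 (`C=CCn1c(=O)n([C@H]2CO[C@@H](CO)C2)c2nc(N)nc(O)c21`) gives 83 uM as the nearest value, and compound 2 (`CCCn1c(=O)n(C2CCC(COC(C)=O)O2)c2nc(NC(C)=O)nc(O)c21`) gives 154 uM as the furthest one. For the measured compounds named here, no two measured compounds differ in only one place, so no measured step isolates a single change.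

The step to compound 4 (`CN(C)CCCn1c(=O)n(C2OC(CO)[C@@H](O)[C@H]2O)c2nc(N)nc(O)c21`) is 2-(dimethylamino)ethyl in place of 2-phenylethenyl on a saturated chain carbon bound to an aromatic nitrogen and puts 2-(dimethylamino)ethyl in place of 2-phenylethenyl on a saturated chain carbon bound to an aromatic nitrogen. Compound 3 at 83 uM and compound 1 at 103 uM differ in more than one place, yet remain within the scatter of each other. On that limited basis, no step beyond the scatter is expected in this assay in either direction. The estimated step of a 1.1-fold higher number from compound 1 to compound 4 (0.03 log units; within the scatter) is expected to remain small. For compound 4 the expected value is 110 uM with an estimated range of 40 uM to 300 uM in this read-out.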

Compound 4, concentration for half-maximal effect: 194 uM
For compound 4 the middle estimate is 1.8-fold (0.25 log units) below the measured one; the measured number falls inside the stated range.
By their numbers in this assay, from the lowest: compounds 3, 1, 2 and 4 (each within the scatter of the next, the first and the last beyond it).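

In this assay, the series now has one step that isolates a single change: 2-(dimethylamino)ethyl in place of 2-phenylethenyl on a saturated chain carbon bound to an aromatic nitrogen gives a 1.9-fold higher number from compound 1 to compound 4 (0.27 log units; within the scatter). At this place, the six-membered aromatic ring and the double bond outside it can therefore leave, and a chain nitrogen can enter, without a step beyond the scatter in this read-out. Nothing available explains this result or bears on its cause.

On these data alone, it remains open whether a carboxylic acid or a longer unbranched alkyl chain at the same place would give a step beyond the scatter. For the compounds shown here, with only one step at this place, it is also unclear whether the same change would behave alike on the other sugar-like groups.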